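Exchanging the aryl group of compound 2 for a bromophenyl

This account rests on a few compounds, and the source may have more. Where it says the series, first, only, none or still open, it means among the compounds named here.

Compound 1 `COc1cc(/C=N/Nc2nc(-c3ccc(F)c(F)c3)cs2)cc(Br)c1OC` and compound 2 `COc1cc(/C=N/Nc2nc(-c3ccc(F)c(F)c3)cs2)c(Br)c(Br)c1OC` share one core and differ by a single bromo in place of hydrogen on an aromatic carbon. In a functional assay on A549 cells (Homo sapiens) for inhibition, read by MTT assay, with a stated time of 48 h (on this read-out lower numbers stand for stronger inhibition and higher numbers for weaker inhibition), compound 1 gives 21100 nM, and compound 2 gives 8380 nM. Within the data shown here, the step of a 2.5-fold lower number from compound 1 to compound 2 (0.40 log units; beyond the scatter) is modest but beyond the scatter, so compound 2 holds the lower of the two numbers measured so far.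

Compound 3 `COc1cc(/C=N/Nc2nc(-c3ccc(Br)cc3)cs2)c(Br)c(Br)c1OC` keeps both bromines of compound 2 and changes instead the group on the five-membered ring: 4-bromophenyl in place of 3,4-difluorophenyl on an aromatic carbon. Among the measured compounds shown here, no measured step touches this position; the only step known, a 2.5-fold lower number from compound 1 to compound 2 (0.40 log units; beyond the scatter), concerns another ring and says nothing about exchanging one substituted phenyl for another. With nothing to lean on, the expectation is that compound 3 stays close to compound 2 in this assay, with no step beyond the scatter, though a shift either way cannot be excluded. Compound 3 is therefore estimated at 8400 nM, within a range of 3000 nM to 25000 nM, which corresponds to an expected step of a 1.0-fold higher number from compound 2 to compound 3 (0.00 log units; within the scatter).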

Compound 3, half-maximal inhibitory concentration: 46100 nM
Compound 3: the middle estimate sits 5.5-fold (0.74 log units) below what was measured, outside the stated range (above it).
By their numbers in this assay, from the lowest: compound 2; then compound 1; then compound 3.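

The group on the five-membered ring, next to the ring nitrogen, proves not to be a silent position in this assay: 4-bromophenyl in place of 3,4-difluorophenyl gives a 5.5-fold higher number from compound 2 to compound 3 (0.74 log units; beyond the scatter). Among these compounds, the earlier step, a 2.5-fold lower number from compound 1 to compound 2 (0.40 log units; beyond the scatter), showed only that the number falls when a bromo is added to the other ring, whereas this change on the five-membered ring moves the number the opposite way, towards weaker inhibition, with both bromines of compound 2 kept in place. No measurement offered here accounts for this loss, so the result stands as an observation without an explanation.

The exchange removes two fluorines and brings in one bromine in a single move, so the compounds shown cannot tell whether the step follows from the loss of the fluorines, from the entry of the bromine, or from both together. They also leave open how this position would read with an unsubstituted phenyl, or with an amine or a carboxylic acid on the phenyl, and whether the same step would appear on the core of compound 1.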